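A Chlorophenyl Urea Variant of a Weak Thioether Series

This account rests on a few compounds, and the source may have more. Where it says the series, first, only, none or still open, it means among the compounds named here.

Compound 2 `Cc1cccc(NC(=O)Nc2ccc(Sc3nc(C)cc(C)n3)cc2)c1` is a urea whose thioether-linked core is shared with compound 3. In a functional assay on KB cells (Homo sapiens) for cytotoxicity, read by MTT assay, with a stated time of 3 days (a lower number here means a stronger inhibitor, a higher number a weaker inhibitor), compound 2 gives 47800 nM. Its ether counterpart, compound 1 `Cc1cccc(NC(=O)Nc2ccc(Oc3nc(C)cc(C)n3)cc2)c1`, differs in the linker alone. In this assay compound 1 reaches only a limit of the assay, > 50000 nM. Among the compounds with values here, compound 2 is thus the only compound here with a numerical value, and that value sits close to the limit of > 50000 nM in this assay, at which 1 of the 2 values shown sits, so it stands among weak inhibitors; with compound 1 at a limit, no ordering between the two can be drawn.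

Compound 3 `Cc1cc(C)nc(Sc2ccc(NC(=O)Nc3ccc(Cl)cc3)cc2)n1` arises from compound 2 by a single exchange: 4-chlorophenyl in place of 3-methylphenyl on an amide-type nitrogen. Within the data shown here, no step between measured compounds touches this nitrogen, so nothing here shows how the aryl group on the urea shifts potency. Compound 3 is expected to stay in the weak range, with the step of a 1.6-fold lower number from compound 2 to compound 3 (0.20 log units; within the scatter) small and most likely within the scatter, perhaps edging toward stronger inhibition. The value of compound 3 in this assay is estimated at 30000 nM, within 8000 nM to 60000 nM.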

Compound 3, half-maximal inhibitory concentration: 10200 nM
For compound 3 the middle estimate is 2.9-fold (0.47 log units) above the measured one; low and high end bracket the measured number.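

In this assay, within the data shown here, the exchange of 3-methylphenyl for 4-chlorophenyl on the amide-type nitrogen gives a 4.7-fold lower number from compound 2 to compound 3 (0.67 log units; beyond the scatter) and so supplies the one readable step in this set. Among these compounds, it shows that the aryl group on this nitrogen can move the number beyond the scatter while the thioether-linked core stays the same, something the earlier compounds could not show. Compound 1 remains at a limit of the assay: the limit of > 50000 nM in this assay, at which 1 of the 3 values shown sits.

The step replaces a methyl group with a chlorine and also moves the substituent to a different place on the ring, so it cannot separate the contribution of the atom from that of its placement. As far as these compounds go, whether the same exchange would have a similar effect in the ether counterpart of compound 1, and how an amine or a carboxylic acid on this aryl ring would shift the number, remains open.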